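Chloro to Methoxy on a Weakly Inhibiting Core

The compounds below may be only part of what the source reports. "The series", "measured", "known", "first", "only" and "open" are said of these compounds alone.

Of the compounds shown here, three have been measured in an assay for inhibition of Dihydrofolate reductase (Bos taurus), using NADPH; on this read-out higher numbers stand for weaker inhibition and lower numbers for stronger inhibition. Compound 1 `COc1cccc(N2C(N)=NC(N)=NC23CCCCC3)c1` reaches only a limit of the assay, > 100000 nM. Compound 2 `COc1ccc(N2C(N)=NC(N)=NC23CCCCC3)cc1` likewise reaches only a limit, > 100000 nM. Compound 3 `CC1(C)N=C(N)N=C(Nc2cccc(Cl)c2)N1` stands at a limit of the assay as well, > 100000 nM. Every value shown thus sits at the same limit (the limit of > 100000 nM in this assay, at which 3 of the 3 values shown sit), so compound 3 cannot be ranked against any other compound in this set.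

Compound 4 `COc1cccc(NC2=NC(N)=NC(C)(C)N2)c1` differs from compound 3 by methoxy in place of chloro on an aromatic carbon. No measured step between two compounds connects this change to a shift in this assay; because compound 1 and compound 2 also sit at the limit (the limit of > 100000 nM in this assay, at which 3 of the 3 values shown sit), a methoxy group has not yet shown a value beyond it. The step from compound 3 to compound 4 is therefore expected to be a step that the limit leaves unreadable from compound 3 to compound 4, none beyond the scatter. For compound 4 the estimate in this assay is 200000 nM, with a range from 50000 nM to 1000000 nM, and most likely the assay will again report only a limit.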

Compound 4, half-maximal inhibitory concentration: > 100000 nM
Compound 4 was reported as a limit; the forecaster's own chance of this, stated with the estimate: 85%; the middle value does not contradict the limit.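

Compound 3 and compound 4 both stand at a limit of the assay, so no step between them can be read: the limit of > 100000 nM in this assay, at which 4 of the 4 values shown sit.

The compounds shown leave open whether methoxy in place of chloro changes inhibition in this assay at all.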